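Swapping bromo for methoxy at the acetamide carbon

The source may hold more compounds than are shown below. What is called first, only, known or untested is meant among the compounds shown, and "the series" means these compounds.

Measured compounds:
compound 1 `COc1ccc(CN(C(=O)CCl)c2cc(OC)c(OC)c(OC)c2)cc1O`: 250 nM
compound 2 `COc1ccc(CN(C(=O)C=C(C)C)c2cc(OC)c(OC)c(OC)c2)cc1O`: 290 nM
compound 3 `COc1ccc(CN(C(=O)CBr)c2cc(OC)c(OC)c(OC)c2)cc1O`: 68 nM

In a functional assay on HCT-116 cells (Homo sapiens) for inhibition, read by MTT assay, with a stated time of 48 h (a higher number here means a weaker inhibitor, a lower number a stronger inhibitor), compound 3 stands lowest of the three numbers. Its nearest neighbour is compound 1, separated by a 3.7-fold lower number from compound 1 to compound 3 (0.57 log units; beyond the scatter), and the furthest is compound 2, separated by a 4.3-fold lower number from compound 2 to compound 3 (0.63 log units; beyond the scatter); both gaps lie beyond the scatter, so compound 3 can be called the strongest inhibitor of the set. Compounds 1 and 2 themselves sit within the scatter of one another, as a 1.2-fold higher number from compound 1 to compound 2 (0.06 log units; within the scatter) shows.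

Compound 4 `COCC(=O)N(Cc1ccc(OC)c(O)c1)c1cc(OC)c(OC)c(OC)c1` is the next step from compound 3: methoxy in place of bromo on a saturated chain carbon bound to a carbonyl carbon. Going by the values given here, the one measured step at this carbon, a 3.7-fold lower number from compound 1 to compound 3 (0.57 log units; beyond the scatter), exchanges one halogen for another and is modest; no measured compound carries methoxy or any non-halogen group at this position, so that step bears on compound 4 only indirectly. Since the two halogen-bearing compounds differ and the non-halogen compound 2 is among the weaker ones, the number for compound 4 is expected to rise, and the step of a 10-fold higher number from compound 3 to compound 4 (1.01 log units; beyond the scatter) is estimated to be at least as large as the halogen swap. The estimate for compound 4 is 700 nM, with a range from 200 nM to 3000 nM.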

Compound 4, half-maximal inhibitory concentration: 230 nM
Beside the measured number, compound 4's estimate is 3.0-fold (0.48 log units) above it, within the range that was stated.
By their numbers in this assay, from the lowest: compound 3; then compounds 4, 1 and 2 (each within the scatter of the next).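

In this assay, methoxy in place of bromo on a saturated chain carbon bound to a carbonyl carbon gives a modest step (a 3.4-fold higher number from compound 3 to compound 4 (0.53 log units; beyond the scatter)), so the earlier halogen swap is now joined by a direct reading of a non-halogen group at this carbon. Methoxy cannot be told apart from chloro at this carbon (a 1.1-fold lower number from compound 1 to compound 4 (0.04 log units; within the scatter)), and methoxymethyl on the carbonyl carbon likewise cannot be told apart from 2-methylprop-1-en-1-yl (a 1.3-fold lower number from compound 2 to compound 4 (0.10 log units; within the scatter)), as both steps lie within the scatter. Compound 3 is therefore the strongest inhibitor of the four, its bromo being the only group shown here that stands apart from the others, and nothing available explains this result.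

The compounds shown leave open whether iodo at this carbon would stand with bromo or with chloro, and whether an amine, a hydroxy group or a longer ether such as ethoxy would fall level with methoxy. They also leave open whether the gap between bromo and the other groups would hold in any cell line other than the one in this assay.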